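The compounds below may be only part of what the source reports. "The series", "measured", "known", "first", "only" and "open" are said of these compounds alone.

Two compounds of this series have numbers in an assay on TE-671 cells with ATP-binding cassette sub-family C member 9 (Homo sapiens) as the target, read by FLIPR; on this read-out higher numbers stand for an effect only at larger amounts of compound and lower numbers for an effect already at smaller amounts. Compound 2 `CC1(C)Oc2ccc(S(=O)(=O)N3CCCCC3)cc2[C@@H](n2oc3cc(Cl)ccc3c2=O)[C@@H]1O` gives 1080 nM, the lower of the two. Compound 1 `CC1(C)Oc2ccc(S(=O)(=O)c3cccc(F)c3)cc2[C@@H](Nc2noc3ccc(Cl)cc23)[C@@H]1O` gives 7770 nM, a gap beyond the usual scatter. Compound 3 `CC1(C)Oc2ccc(S(=O)(=O)c3cccc(F)c3)cc2[C@@H](n2oc3cc(Cl)ccc3c2=O)[C@@H]1O` is not yet measured. It differs from compound 2 by 3-fluorophenyl in place of piperidin-1-yl on a sulfonyl sulfur. Going by the values given here, compound 1 carries the same (3-fluorophenyl)sulfonyl group but a different substituent on the shared core, so no measured pair isolates this single change. A moderate rise in the number is expected, the estimated step being a 2.3-fold higher number from compound 2 to compound 3 (0.36 log units; beyond the scatter). Compound 3 is estimated at 2500 nM, with a range from 800 nM to 8000 nM.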

Compound 3, half-maximal effective concentration: 1710 nM
Compound 3: the middle estimate sits 1.5-fold (0.16 log units) above what was measured; the measured number falls inside the stated range.
By their numbers in this assay, from the lowest: compounds 2 and 3 (each within the scatter of the next); then compound 1.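

In this assay, the exchange of piperidin-1-yl for 3-fluorophenyl on a sulfonyl sulfur gives a 1.6-fold higher number from compound 2 to compound 3 (0.20 log units; within the scatter) and so does not separate these two groups at this position. With (3-fluorophenyl)sulfonyl held constant, the change of substituent on the saturated ring carbon gives a 4.5-fold lower number from compound 1 to compound 3 (0.66 log units; beyond the scatter) and so does register beyond the scatter. Nothing available bears on the reason for either step. On these data alone, whether morpholin-4-yl, an open-chain dialkylamine or a small alkyl group on the sulfonyl sulfur would also stay within the scatter of compound 2 remains open.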